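The source may report more compounds than this note shows. Statements on the series, on what has been measured and on what is new or still open speak of the compounds shown alone.

Compound 3 `CC#CC(CC(=O)O)c1ccc(OCc2ccc(C(=O)N3CCN(c4cccc(F)c4)CC3)s2)cc1` gives 97 nM in a functional assay on HEK293 cells for agonist activity at Free fatty acid receptor 1 (Homo sapiens), read by fluorescence and calcium flux (a higher number here means that more compound is needed for the effect, a lower number that less compound is needed), the lowest of the two numbers reported. Compound 2 `CC#CC(CC(=O)O)c1ccc(OCc2ccc(C(=O)N3CCN(c4ccc(C(C)(C)C)cc4)CC3)s2)cc1` gives 417 nM in this assay, and the step from it is a 4.3-fold lower number from compound 2 to compound 3 (0.63 log units; beyond the scatter). For compound 1 `CC#CC(CC(=O)O)c1ccc(OCc2ccc(C(=O)N3CCN(C)CC3)s2)cc1` this assay reports only a limit, > 5000 nM (the limit of > 5000 nM in this assay, at which 1 of the 3 values shown sits). The two steps away from that limit are large: an at least 11-fold lower number from compound 1 to compound 2 (1.07 log units; beyond the scatter) and an at least 51-fold lower number from compound 1 to compound 3 (1.71 log units; beyond the scatter).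

Compound 4 `CC#CC(CC(=O)O)c1ccc(OCc2ccc(C(=O)N3CCN(c4cccc([N+](=O)[O-])c4)CC3)s2)cc1` differs from compound 3 by nitro in place of fluoro on an aromatic carbon of a six-membered aromatic ring of carbon only, meta to a large group. Going by the values given here, none of the measured steps swaps one substituent for another on that ring while keeping the ring in place; the only step among ring-bearing compounds is the modest one a 4.3-fold lower number from compound 2 to compound 3 (0.63 log units; beyond the scatter), which exchanges the whole aryl group. The author therefore expects no step beyond the scatter for compound 4, an estimated 1.5-fold higher number from compound 3 to compound 4 (0.19 log units; within the scatter) in this assay. Compound 4 is estimated at 150 nM, within 40 nM to 600 nM.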

Compound 4, half-maximal effective concentration: 187 nM
For compound 4 the middle estimate is 1.2-fold (0.10 log units) below the measured one, within the range that was stated.
By their numbers in this assay, from the lowest: compounds 3 and 4 (each within the scatter of the next); then compound 2. At a limit, above all of these: compound 1.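

In this assay, nitro with its 3 heavy atoms takes the place of the single fluorine on an aromatic carbon, meta to a large group, with no change that stands out from the scatter: a 1.9-fold higher number from compound 3 to compound 4 (0.29 log units; within the scatter). Compound 4 also repeats what compound 3 showed against the other two compounds, with a modest step, a 2.2-fold lower number from compound 2 to compound 4 (0.35 log units; beyond the scatter), and a large one, an at least 26-fold lower number from compound 1 to compound 4 (1.42 log units; beyond the scatter). The value of compound 1 in that large step is a limit: the limit of > 5000 nM in this assay, at which 1 of the 4 values shown sits.

Going by these compounds, what an amine, a methoxy group or a nitrile would give at this same place stays open, as does a phenyl group with no substituent at all. With only fluoro and nitro on this ring at this place, the compounds shown give no account of which features of the substituent matter here.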